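Ring Closure at the Chain End: Epoxide Replaces Ether

The compounds below may be only part of what the source reports. "The series", "measured", "known", "first", "only" and "open" are said of these compounds alone.

Three compounds of one series have been measured in a physicochemical assay for lipophilicity; on this read-out lower numbers stand for lower lipophilicity and higher numbers for higher lipophilicity:
compound 1 `CCOC(=O)/C=C(C)/C=C/CC(C)CCCC(C)(C)OC(C)=O` gives 5.57;
compound 2 `CCOC(=O)/C=C(C)/C=C/CC(C)CCCC(C)(C)OCC` gives 6.08;
compound 3 `CCNC(=O)OC(C)(C)CCCC(C)C/C=C/C(C)=C/C(=O)OCC` gives 5.65.

Compound 2 stands highest of the three, with compound 3 nearest and compound 1 furthest, both beyond the scatter. Compound 4 `CCOC(=O)/C=C(C)/C=C/CC(C)CCC1OC1(C)C` differs from compound 2 in one place: 3,3-dimethyloxiran-2-yl in place of 2-ethoxy-2-methylpropyl on a saturated chain carbon, four bonds along the chain from a double-bonded chain carbon. The measured steps that touch the same oxygen on a saturated carbon are a number 0.51 log units higher from compound 1 to compound 2 (beyond the scatter) and a number 0.43 log units lower from compound 2 to compound 3 (beyond the scatter), both modest. For the measured compounds named here, no measured step removes that side group and closes a ring, so the direction and size here rest on the change itself. Compound 4 is expected to fall clearly, since a smaller group enters; the estimated step is a number 0.98 log units lower from compound 2 to compound 4 (beyond the scatter). Compound 4 is therefore estimated at 5.1, within 4.6 to 5.6.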

Compound 4, partition coefficient: 4.76
The estimate for compound 4 lay 0.34 log units above the measured number; the measured number falls inside the stated range.
By their numbers in this assay, from the lowest: compound 4; then compounds 1 and 3 (each within the scatter of the next); then compound 2.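

In this assay, 3,3-dimethyloxiran-2-yl in place of 2-ethoxy-2-methylpropyl gives a number 1.32 log units lower from compound 2 to compound 4 (beyond the scatter), the largest step yet seen at this chain end. Unlike the earlier steps, which changed only what sits on the oxygen, this one replaces a side group of 7 heavy atoms with one of 5 and adds a three-membered ring, while the hydrogen-bond acceptor count stays the same. No supporting evidence explains the size of this step.

The compounds shown do not separate the effect of the ring from that of the smaller group. From the compounds shown here alone, how a cyclopropyl ring or a free hydroxyl would compare at this position remains open.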